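Phenyl on the Amide Nitrogen of Compound 1

The compounds below may be only part of what the source reports. "The series", "measured", "known", "first", "only" and "open" are said of these compounds alone.

Compound 1 `COc1ccc(-n2nc(C(N)=O)nc2-c2cc(OC)c(OC)c(OC)c2)cc1` carries a plain carbamoyl group on its shared core. In a functional assay on the whole organism for inhibition, with Rattus norvegicus as the target, read by paw edema, with stated times of 30 min and 1 h, at a dose of 0.28 mmol/kg by the oral route (on this read-out higher numbers stand for more inhibition at the one dose given (going by the name of the read-out) and lower numbers for less inhibition), compound 1 gives 40%, the lowest of the three numbers at hand. Compound 2 `CNC(=O)c1nc(-c2cc(OC)c(OC)c(OC)c2)n(-c2ccc(OC)cc2)n1` differs from it by a methyl in place of hydrogen on the amide-type nitrogen, and in this assay compound 2 gives 56%; the step is a number 16 percentage points higher from compound 1 to compound 2 (beyond the scatter). Compound 3 `COc1ccc(-n2nc(C(=O)Nc3ccc(C(=O)O)cc3)nc2-c2cc(OC)c(OC)c(OC)c2)cc1` carries a 4-carboxyphenyl on that same nitrogen, and in this assay compound 3 gives 50%; the step is a number 10 percentage points higher from compound 1 to compound 3 (within the scatter), and between the two substituted amides it is a number 6 percentage points lower from compound 2 to compound 3 (within the scatter).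

Compound 4 `COc1ccc(-n2nc(C(=O)Nc3ccccc3)nc2-c2cc(OC)c(OC)c(OC)c2)cc1` has not yet been measured. Its difference from compound 1 is phenyl in place of hydrogen on an amide-type nitrogen. Of the two earlier substitutions on the amide nitrogen, the methyl raised the number beyond the scatter, while the 4-carboxyphenyl gave a number within the scatter of compound 1. A phenyl is the 4-carboxyphenyl of compound 3 without its carboxylic acid, so a small rise, or no change beyond the scatter, is the reasonable expectation. For compound 4 the expected step is a number 10 percentage points higher from compound 1 to compound 4 (within the scatter). Compound 4 is therefore estimated at 50%, with a likely range from 36% to 64%.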

Compound 4, a percentage reported as inhibition, in the whole organism at one dose (the size of the read-out at that dose, not a potency): 45%
For compound 4 the middle estimate is 5 percentage points above the measured one; measured number inside the range.
By their numbers in this assay, from the lowest: compounds 1, 4, 3 and 2 (each within the scatter of the next, the first and the last beyond it).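

In this assay, placing a bare phenyl on the amide-type nitrogen gives a number 5 percentage points higher from compound 1 to compound 4 (within the scatter) and so does not separate compound 4 from the plain carbamoyl of compound 1. Removing the carboxy group from the aromatic carbon gives a number 5 percentage points lower from compound 3 to compound 4 (within the scatter) and shows that, at this one dose, the read-out cannot distinguish the phenyl amide with the acid group from the one without it. The clearest new contrast is with the small substituent: phenyl in place of methyl gives a number 11 percentage points lower from compound 2 to compound 4 (beyond the scatter) as a modest step, whereas the 4-carboxyphenyl of compound 3 stayed within the scatter of the methyl of compound 2.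

Going by these compounds, whether a longer chain such as ethyl or propyl on this nitrogen, or an amine on the phenyl ring, would match or pass the methyl of compound 2 remains open. The data at hand offer no measured explanation for the gap between the methyl and phenyl amides.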